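Swapping the aryl group at the acid-bearing carbon

The source may report more compounds than this note shows. Statements on the series, on what has been measured and on what is new or still open speak of the compounds shown alone.

Measured compounds:
compound 1 `N#Cc1ccc(OCc2ccsc2)cc1OC(C(=O)O)c1ccccc1Br`: 51 nM
compound 2 `COc1ccccc1C(Oc1cc(OCc2ccsc2)ccc1C#N)C(=O)O`: 529 nM

In an assay on A10 cells for antagonist activity at Endothelin-1 receptor (Rattus norvegicus) (on this read-out higher numbers stand for weaker inhibition and lower numbers for stronger inhibition), compound 2 gives the higher of the two numbers; compound 1 gives the lower one, and the step of a 10-fold higher number from compound 1 to compound 2 (1.02 log units; beyond the scatter) is large. Compound 3 `N#Cc1ccc(OCc2ccsc2)cc1OC(C(=O)O)c1ccc(Cl)cc1` differs from compound 2 in one place: 4-chlorophenyl in place of 2-methoxyphenyl on a saturated chain carbon bound to a carbonyl carbon and an oxygen on an aromatic ring. Going by the values given here, only one measured step bears on this, and it shows that removing the methoxy group in favour of a halogen, as in compound 1, lowers the number markedly. A similar move toward a halogen is expected here, though the halogen and its place on the ring differ, so a step of a 3.5-fold lower number from compound 2 to compound 3 (0.55 log units; beyond the scatter) is estimated. Compound 3 is expected to give 150 nM, between 40 nM and 600 nM.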

Compound 3, half-maximal inhibitory concentration: 504 nM
Compound 3: the middle estimate sits 3.4-fold (0.53 log units) below what was measured, and the stated range covers the measured number.
By their numbers in this assay, from the lowest: compound 1; then compounds 3 and 2 (each within the scatter of the next).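

Replacing the 2-methoxyphenyl with 4-chlorophenyl leaves the number essentially unchanged in this assay, with a 1.0-fold lower number from compound 2 to compound 3 (0.02 log units; within the scatter), so a halogen on this ring does not by itself give the low number of compound 1. Against the 2-bromophenyl group the picture differs, with a 9.9-fold higher number from compound 1 to compound 3 (0.99 log units; beyond the scatter), and of the three aryl groups only 2-bromophenyl stands apart. Nothing available explains this difference.

From the compounds shown here alone, the halogen and its place on the ring change together in that last step, so which of the two matters stays open. Going by these compounds, how a plain phenyl ring or a ring carrying a methyl group would behave at this carbon also remains unknown.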